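A few compounds are considered here, and "the series" means these few. Any claim that something is new, unique, unknown or untested is made for them only; others in the source may bear on it.

Measured compounds:
compound 1, `CC[C@@H]1C(=O)N(C)c2cnc(-n3ccnc3-c3ccc(F)cc3)nc2N1[C@H]1CCOC1`: 33 nM
compound 2, `CCC1C(=O)N(C)c2cnc(-n3ccnc3-c3ccc(F)cc3)nc2N1C1CCC(F)(F)C1`: 13 nM
compound 3, `CC[C@@H]1C(=O)N(C)c2cnc(-n3ccnc3-c3ccccc3)nc2N1[C@@H]1CCOC1`: 21 nM

Of the compounds shown here, three have been measured in an assay on isolated protein for inhibition of serine/threonine-protein kinase PLK2 (Homo sapiens), read by TR-FRET, with a stated time of 60 min; a lower number here means a stronger inhibitor, a higher number a weaker inhibitor. Compound 1 gives 33 nM, compound 2 gives 13 nM and compound 3 gives 21 nM. Compound 3 holds the middle of the three numbers; both compound 1 and compound 2 lie within the usual scatter of it, so the three compounds cannot be told apart on these values.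

Compound 4, `CC[C@@H]1C(=O)N(C)c2cnc(-n3ccnc3-c3ccccc3)nc2N1CCC(F)(F)F`, has not yet been measured. It differs from compound 3 in one place: 3,3,3-trifluoropropyl in place of oxolan-3-yl on a nitrogen on an aromatic ring in a ring. Among the compounds with values here, no pair of measured compounds shows this change, so there is no measured step to lean on. The nearest hint is compound 2, where a ring without an oxygen carries two fluorine atoms and the number stays within the scatter of compound 3. On that basis compound 4 is expected to remain close to compound 3 in this assay, with the step of a 1.4-fold higher number from compound 3 to compound 4 (0.15 log units; within the scatter) estimated to be no larger than the scatter, in no firm direction. The estimated value for compound 4 is 30 nM, with a range from 10 nM to 90 nM.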

Compound 4, half-maximal inhibitory concentration: 9 nM
Estimate against measurement, compound 4: 3.3-fold (0.52 log units) above; measured number outside the range, below it.
By their numbers in this assay, from the lowest: compounds 4, 2, 3 and 1 (each within the scatter of the next, the first and the last beyond it).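

In this assay, within the data shown here, putting 3,3,3-trifluoropropyl in place of oxolan-3-yl gives a 2.3-fold lower number from compound 3 to compound 4 (0.37 log units; beyond the scatter), a modest change and the only step between compounds differing in one place so far. It shows that, on this nitrogen next to the ring atom that bears an ethyl group, the group need not contain a ring or a hydrogen-bond acceptor for the number to stay low, and that an open chain can give a lower number than oxolan-3-yl. No measurement available here accounts for the step.

This single change removes the ring and its oxygen and adds the fluorine atoms all at once, so the compounds shown cannot say which of these differences matters. From the compounds shown here alone, a plain propyl chain at this position would separate the fluorine atoms from the open chain, while a longer chain or a chain ending in an amine remains open.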